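The compounds below may be only part of what the source reports. "The series", "measured", "known", "first", "only" and "open" are said of these compounds alone.

Compound 1 `O=S(=O)(c1ccc2c(c1)C1CNCC2C1)N1CC1` is the strongest binder among the three compounds measured in an assay on HEK293 cells for binding affinity to Neuronal acetylcholine receptor; alpha4/beta2 (Homo sapiens) (a higher number here means a weaker inhibitor, a lower number a stronger inhibitor), where compound 1 gives 2 nM. Compound 2 `O=S(=O)(c1ccc2c(c1)C1CNCC2C1)N1CCCC1` sits close to it: in this assay compound 2 gives 3.1 nM, and the change of pyrrolidin-1-yl in place of aziridin-1-yl on a sulfonyl sulfur moves the number only a 1.6-fold higher number from compound 1 to compound 2 (0.19 log units; within the scatter). Compound 3 `Oc1cccc2c1C1CNCC2C1`, which carries a hydroxyl on the shared core instead of a sulfonyl group, gives 1700 nM in this assay.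

Compound 4 `Fc1ccc2c(c1)C1CNCC2C1` has not yet been measured. It differs from compound 1 in this way: one fluorine atom in place of a group of 6 heavy atoms (2 carbon, 1 nitrogen, 2 oxygen, 1 sulfur; one three-membered non-aromatic ring with 1 hetero atom), on an aromatic carbon The change sits on an aromatic carbon of a six-membered aromatic ring of carbon only, part of a fused or bridged system of three rings.

Going by the values given here, no measured step removes the whole sulfonyl group, so the step from compound 1 to compound 2 is the only one that touches this part of the molecule, and it is small. The values of compound 1 and compound 3 show that a core without the sulfonyl group can bind far more weakly. Compound 4 is therefore expected to show a clearly weaker binding than compound 1, a step of a 150-fold higher number from compound 1 to compound 4 (2.18 log units; beyond the scatter), and its value in this assay is estimated at 300 nM, within a range from 30 nM to 3000 nM.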

Compound 4, inhibition constant: 1.1 nM
For compound 4 the middle estimate is 270-fold (2.44 log units) above the measured one; measured number below the stated range.
By their numbers in this assay, from the lowest: compounds 4, 1 and 2 (each within the scatter of the next, the first and the last beyond it); then compound 3.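

Replacing the whole group of 6 heavy atoms with one fluorine atom on this aromatic carbon gives a 1.8-fold lower number from compound 1 to compound 4 (0.26 log units; within the scatter) in this assay, so the two compounds cannot be told apart. The earlier step changed only the ring on the sulfonyl sulfur, whereas this one shows that binding at the level of compound 1 does not require a sulfonyl group at this position, even though the group that leaves counts 2 hydrogen-bond acceptors and fluoro counts 0. Nothing available explains why such different groups give matching results.

The compounds shown hold only these sulfonyl groups and fluoro at this position, so the result of an amine or a carboxylic acid there remains open. It is also unknown whether plain hydrogen or a longer chain would fit this pattern.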